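Testing a Side-Chain Swap on an Unmeasured Compound

This account rests on a few compounds, and the source may have more. Where it says the series, first, only, none or still open, it means among the compounds named here.

In a functional assay on DU-145 cells (Homo sapiens) for cytotoxicity, read by trypan blue exclusion, with a stated time of 96 h (on this read-out lower numbers stand for stronger inhibition and higher numbers for weaker inhibition), compound 1 `COC(=O)[C@H](C)Nc1cc(CS(=O)(=O)/C=C/c2c(OC)cc(OC)cc2OC)ccc1OC` gives 750 nM, while compound 2 `COC(=O)C(F)(F)Nc1cc(CS(=O)(=O)/C=C/c2c(OC)cc(OC)cc2OC)ccc1OC` gives 250 nM, the lower of these two numbers. For the measured compounds named here, the only measured step is a 3.0-fold lower number from compound 1 to compound 2 (0.48 log units; beyond the scatter). It places difluoro(methoxycarbonyl)methyl where 1-(methoxycarbonyl)ethyl stood, on a nitrogen on an aromatic ring.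

Compound 3 `COC(=O)C(C)(C)Nc1cc(CS(=O)(=O)/C=C/c2c(OC)cc(OC)cc2OC)ccc1OC` has not yet been measured. It keeps the shared core but carries 1-(methoxycarbonyl)-1-methylethyl in place of difluoro(methoxycarbonyl)methyl, at that same place: 1-(methoxycarbonyl)-1-methylethyl in place of difluoro(methoxycarbonyl)methyl on a nitrogen on an aromatic ring. The fluorines therefore leave, and methyl groups stand on the carbon that held them. Compound 1 also lacks the fluorines, and its value of 750 nM is the closest guide available. Going by the values given here, one modest step is thin evidence, and no measured compound shows how the second methyl group behaves. Even so, a step of similar size towards a higher number seems most likely. The expected change is a 2.4-fold higher number from compound 2 to compound 3 (0.38 log units; beyond the scatter). In this assay, the estimate for compound 3 is 600 nM, with an expected range from 200 nM to 1800 nM.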

Compound 3, half-maximal inhibitory concentration: 2500 nM
Beside the measured number, compound 3's estimate is 4.2-fold (0.62 log units) below it; the measured number lies above the stated range.
By their numbers in this assay, from the lowest: compound 2; then compound 1; then compound 3.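

In this assay, putting 1-(methoxycarbonyl)-1-methylethyl in place of difluoro(methoxycarbonyl)methyl gives a 10-fold higher number from compound 2 to compound 3 (1.00 log units; beyond the scatter), the largest step seen so far at this place on the nitrogen, even though the leaving and entering groups have the same count of heavy atoms and the same hydrogen-bond counts. The earlier pair could not separate the loss of the fluorines from the effect of the methyl groups, but putting 1-(methoxycarbonyl)-1-methylethyl in place of 1-(methoxycarbonyl)ethyl gives a 3.3-fold higher number from compound 1 to compound 3 (0.52 log units; beyond the scatter), so a further methyl group on that carbon also raises the number when no fluorine is involved. Among these three compounds, then, the side chain on the nitrogen clearly changes the result, and compound 1 falls between the difluoro and the dimethyl compounds. Nothing available here explains why these changes move the number as they do.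

The compounds shown leave open how (methoxycarbonyl)methyl, with only hydrogens on that carbon, or a side chain carrying a single fluorine would compare. They also leave open whether the methyl ester itself matters, since a carboxylic acid or an amide in its place does not appear among them.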